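From a chlorophenyl amide to a dibromophenyl amide

This account rests on a few compounds, and the source may have more. Where it says the series, first, only, none or still open, it means among the compounds named here.

Three measured compounds share one core and differ only in the aryl group on the amide nitrogen. Compound 1 `COc1cccc(NC(=O)COc2ccc3cc(/C=C4/SC(=O)NC4=O)ccc3c2)c1` carries a 3-methoxyphenyl group, and in an assay on isolated protein for inhibition of histone deacetylase 8 (Homo sapiens), with a stated time of 1 h (a higher number here means a weaker inhibitor, a lower number a stronger inhibitor), compound 1 gives 7600 nM. Compound 2 `Cc1cccc(NC(=O)COc2ccc3cc(/C=C4/SC(=O)NC4=O)ccc3c2)n1` carries a 6-methylpyridin-2-yl group, and in this assay compound 2 gives 7500 nM; the change a 1.0-fold lower number from compound 1 to compound 2 (0.01 log units; within the scatter). Compound 3 `O=C(COc1ccc2cc(/C=C3/SC(=O)NC3=O)ccc2c1)Nc1cccc(Cl)c1` carries a 3-chlorophenyl group. For compound 3 this assay reports only a limit, > 50000 nM, which places compound 3 at the weak end of the three (the limit of > 50000 nM in this assay, at which 1 of the 3 values shown sits). Both changes toward it were sizeable: an at least 6.5-fold higher number from compound 1 to compound 3 (0.81 log units; beyond the scatter) and an at least 6.6-fold higher number from compound 2 to compound 3 (0.82 log units; beyond the scatter).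

Compound 4 `O=C(COc1ccc2cc(/C=C3/SC(=O)NC3=O)ccc2c1)Nc1ccc(Br)c(Br)c1` is not yet measured; it differs from compound 3 by 3,4-dibromophenyl in place of 3-chlorophenyl on an amide-type nitrogen. Among the measured compounds shown here, no measured step exchanges one halogen for another, so the two steps into compound 3 are the only guide, and they show only that compound 3 already sits at the limit. For compound 4 no movement beyond the scatter is expected, a step that the limit leaves unreadable from compound 3 to compound 4. Compound 4 is therefore estimated at 60000 nM, within 20000 nM to 200000 nM, and most likely again reported only as a limit.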

Compound 4, half-maximal inhibitory concentration: > 50000 nM
Compound 4 gave a limit, no number (the forecaster's own chance of this, stated with the estimate: 70%); the middle value lies beyond the limit too.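

In this assay compound 4 gives only a limit (> 50000 nM), so a second halogen-bearing phenyl group on the amide-type nitrogen now sits at the weak end: the limit of > 50000 nM in this assay, at which 2 of the 4 values shown sit. Against the two compounds that have real numbers, the change to 3,4-dibromophenyl is beyond the scatter, with an at least 6.5-fold higher number from compound 1 to compound 4 (0.81 log units; beyond the scatter) and an at least 6.6-fold higher number from compound 2 to compound 4 (0.82 log units; beyond the scatter) as the two steps, so the loss seen with 3-chlorophenyl also holds for a phenyl group carrying two bromines. The step between compound 3 and compound 4 cannot be read, as both are limits.

As far as these compounds go, how far compound 3 and compound 4 lie beyond the limit stays unknown, so the two halogen patterns cannot be ranked. Also open, from the compounds shown here alone, is whether an amine or a carboxylic acid on the phenyl ring, in place of the halogens, would bring back a measurable number.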